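The source may hold more compounds than are shown below. What is called first, only, known or untested is meant among the compounds shown, and "the series" means these compounds.

Within the data shown here, compound 3 `O=[N+]([O-])c1ccccc1-c1nc2cc(C(F)(F)F)ccc2[nH]1` reaches 93.2% in a functional assay on aorta (Rattus norvegicus, strain Wistar) for inhibition, with a stated time of 60 min (a lower number here means a smaller maximal response, a higher number a larger maximal response), the highest of the three numbers measured so far. Compound 2 `FC(F)(F)c1ccc2[nH]c(-c3ccccc3)nc2c1` gives 91.2%, and the gap a number 2 percentage points higher from compound 2 to compound 3 (within the scatter) shows that the nitro group changed little. Compound 1 `CCCOc1ccc(-c2nc3cc(C(F)(F)F)ccc3[nH]2)cc1` gives 51%, the lowest of the three, and the step of a number 40.2 percentage points higher from compound 1 to compound 2 (beyond the scatter) was the only large one seen.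

Compound 4 `COc1ccccc1-c1nc2cc(C(F)(F)F)ccc2[nH]1` differs from compound 3 in one place: methoxy in place of nitro on an aromatic carbon. Among the measured compounds shown here, two measured steps bear on this. The step from compound 2 to compound 3 says that removing the nitro group should matter little. The step from compound 1 to compound 2, however, shows that an alkoxy group on the same core cost a large part of the maximal response, though propoxy is longer than methoxy. Compound 4 is therefore expected to fall somewhat, by about a number 15.2 percentage points lower from compound 3 to compound 4 (beyond the scatter), with an estimated response of 78%, likely between 55% and 95%.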

Compound 4, largest response reached (Emax), in percent of the reference or control that the assay uses: 75.1%
Compound 4: the middle estimate sits 2.9 percentage points above what was measured; measured number inside the range.
By their numbers in this assay, from the lowest: compound 1; then compound 4; then compounds 2 and 3 (each within the scatter of the next).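

In this assay, the aromatic carbon ortho to a large group turns out to respond to which group it carries, not simply to whether it is substituted. Nitro there left the response level with hydrogen, but methoxy in place of hydrogen gives a number 16.1 percentage points lower from compound 2 to compound 4 (beyond the scatter) and stands apart from the unsubstituted compound, a drop that compound 3 gave no hint of. Exchanging one group for the other gives a number 18.1 percentage points lower from compound 3 to compound 4 (beyond the scatter) as a modest change at a single carbon, and no measurement here explains the difference between nitro and methoxy.

The compounds shown leave open whether an amine, a hydroxy group or a longer chain such as ethoxy at this carbon would track methoxy or nitro. They also leave open whether methoxy on another carbon of that ring would produce a similar step.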